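Benzyl ether change at the cytotoxicity limit

This account rests on a few compounds, and the source may have more. Where it says the series, first, only, none or still open, it means among the compounds named here.

- compound 1 `CCOc1c(OC)c(OC)cc2c1C(=O)[C@]1(OC)C=C[C@H]2N(C(=O)OCC(C)C)N1C(=O)OCC(C)C` gives > 300 ug/mL (limit)
- compound 2 `COC(=O)N1[C@@H]2C=C[C@@](OC)(C(=O)c3c2cc(OC)c(OC)c3OCc2ccc(OC)cc2)N1C(=O)OC` gives > 300 ug/mL (limit)

Compound 2 stands in an ADME assay on KB cells (Homo sapiens) for cytotoxicity (a lower number here means that less compound is needed, a higher number that more compound is needed for the effect), at a limit, not a number (> 300 ug/mL). Compound 3 `COC(=O)N1[C@@H]2C=C[C@@](OC)(C(=O)c3c2cc(OC)c(OC)c3OCc2ccccc2F)N1C(=O)OC` has 2-fluorophenyl in place of 4-methoxyphenyl on a saturated chain carbon bound to an oxygen on an aromatic ring. For the measured compounds named here, no measured step gives a size for this change. The only basis is the shared limit (the limit of > 300 ug/mL in this assay, at which 2 of the 2 values shown sit). No change beyond the scatter, in either direction, is expected (a number no higher from compound 2 to compound 3 (the limit leaves the size open)). Compound 3 is estimated at 300 ug/mL (expected range 120 ug/mL to 600 ug/mL).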

Compound 3, concentration for half-maximal effect: 137 ug/mL
Compound 3: middle estimate off by 2.2-fold (0.34 log units), on the high side, and the stated range covers the measured number.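

In this assay, this aryl group on the saturated chain carbon bound to an oxygen on an aromatic ring can bring the read-out to a measured number: 2-fluorophenyl in place of 4-methoxyphenyl gives an at least 2.1-fold lower number from compound 2 to compound 3 (0.34 log units; beyond the scatter). Compound 2 gives > 300 ug/mL, which is a limit and not a number, so only a minimum size can be read for this step: the limit of > 300 ug/mL in this assay, at which 2 of the 3 values shown sit.

Still open, on these data alone, is whether the step belongs to the loss of 4-methoxyphenyl or to the entry of 2-fluorophenyl. A plain unsubstituted benzyl ether would separate the two.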